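The source may hold more compounds than are shown below. What is called first, only, known or untested is meant among the compounds shown, and "the series" means these compounds.

In a functional assay on HepG2 cells (Homo sapiens) for antiproliferative activity, read by MTT assay, with a stated time of 24 h (a higher number here means a weaker inhibitor, a lower number a stronger inhibitor), compound 1 `FC(F)(F)c1ccc(C2CC(c3ccccc3)=NN2c2ccc(-c3ccccc3)nn2)cc1` gives 10000 nM. Compound 2 `Fc1ccc(C2CC(c3ccc(Cl)cc3)=NN2c2ccc(-c3ccccc3)nn2)cc1` gives 10000 nM in this assay, level with compound 1 at the digits shown, so the two stand together within the scatter. Compound 3 `FC(F)(F)c1ccc(C2CC(c3ccc(Cl)cc3)=NN2c2ccc(-c3ccccc3)nn2)cc1` differs from compound 2 by trifluoromethyl in place of fluoro on an aromatic carbon, a change that brings in the group compound 1 already carries. Within the data shown here, with no measured step to guide the size, the step from compound 2 to compound 3 is expected to be no change at the digits printed from compound 2 to compound 3 (within the scatter), nothing beyond the scatter. For compound 3 the expected value in this assay is 10000 nM, within a range from 5000 nM to 20000 nM.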

Compound 3, half-maximal inhibitory concentration: 8330 nM
Estimate against measurement, compound 3: 1.2-fold (0.08 log units) above, and the stated range covers the measured number.
By their numbers in this assay, from the lowest: compounds 3, 1 and 2 (each within the scatter of the next).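

With chloro held in place, the change from 4-fluorophenyl to 4-(trifluoromethyl)phenyl gives a 1.2-fold lower number from compound 2 to compound 3 (0.08 log units; within the scatter) and shows that this position accepts the larger group with no step beyond the scatter. With trifluoromethyl held in place, chloro in place of hydrogen on an aromatic carbon gives a 1.2-fold lower number from compound 1 to compound 3 (0.08 log units; within the scatter) and likewise stays within the scatter. No measurement at hand offers an explanation for either step.

The compounds shown leave open whether an amine or a carboxylic acid on this aromatic carbon would give a step beyond the scatter in this assay and so reveal any dependence on this position.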